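Aryl swaps on the carbonyl, all three at the assay ceiling

The source may report more compounds than this note shows. Statements on the series, on what has been measured and on what is new or still open speak of the compounds shown alone.

Compound 1, `COc1cc(C(=O)C2Sc3nnc(-c4cc(OC)c(OC)c(OC)c4)n3NC2c2ccco2)cc(OC)c1OC`: > 100000 nM
Compound 2, `COc1cc(-c2nnc3n2NC(c2ccco2)C(C(=O)c2ccc(Br)cc2)S3)cc(OC)c1OC`: > 100000 nM
Compound 3, `COc1cc(-c2nnc3n2NC(c2ccco2)C(C(=O)c2cccc(Br)c2)S3)cc(OC)c1OC`: > 100000 nM

The three compounds were tested in a functional assay on HepG2 cells (Homo sapiens) for cytotoxicity, read by MTT assay, with a stated time of 48 h; a lower number here means a stronger inhibitor, a higher number a weaker inhibitor. Compound 1 is reported only as a limit of the assay, > 100000 nM, and not as a number. Compound 2 likewise sits at a limit, > 100000 nM. Compound 3 also sits at a limit, > 100000 nM. All three values rest at the limit of > 100000 nM in this assay, at which 3 of the 3 values shown sit, so none of the exchanges on the carbonyl carbon can be read: a step that the two limits leave unreadable from compound 1 to compound 2, a step that the two limits leave unreadable from compound 1 to compound 3 and a step that the two limits leave unreadable from compound 2 to compound 3 are each a step whose size the two limits hide.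

Compound 4, `COc1cc(-c2nnc3n2NC(c2ccco2)C(C(=O)c2ccc(-c4ccccc4)cc2)S3)cc(OC)c1OC`, has not yet been measured in this assay. It differs from compound 1 in one place: 4-phenylphenyl in place of 3,4,5-trimethoxyphenyl on a carbonyl carbon. For the measured compounds named here, the steps that bear on it are the three exchanges of the aryl group on the carbonyl carbon, and each of them left the value at the assay limit, giving no readable size or direction. The step from compound 1 to compound 4 is therefore expected to be a step that the limit leaves unreadable from compound 1 to compound 4, with the likeliest outcome that compound 4 is again reported only as a limit. Compound 4 is estimated at 150000 nM, within a range from 50000 nM to 500000 nM.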

Compound 4, half-maximal inhibitory concentration: > 100000 nM
Compound 4: no number, only a limit (the forecaster's own chance of this, stated with the estimate: 85%); the middle value does not contradict the limit.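

Compound 4 is likewise reported only as a limit in this assay, > 100000 nM. Its steps from compound 1, compound 2 and compound 3 therefore cannot be read, as all four compounds rest at one limit: the limit of > 100000 nM in this assay, at which 4 of the 4 values shown sit.

The compounds shown leave open whether exchanging the aryl group on the carbonyl carbon shifts the value in this assay at all, and in which direction.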